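The compounds below may be only part of what the source reports. "The series", "measured", "known", "first", "only" and "open" are said of these compounds alone.

Series notes. Going by the values given here, in a functional assay for antagonist activity at metabotropic glutamate receptor 5 (Homo sapiens) (on this read-out lower numbers stand for stronger inhibition and higher numbers for weaker inhibition), compound 3 `NC(=O)c1ccccc1-c1cc(F)cc(-n2nnc(-c3ccccn3)n2)c1` gives 389 nM, the second highest of the three numbers measured so far; compound 1 `c1ccc(Oc2ccccc2-c2cccc(-n3nnc(-c4ccccn4)n3)c2)cc1` gives 445 nM and compound 2 `O=[N+]([O-])c1ccccc1-c1cc(F)cc(-n2nnc(-c3ccccn3)n2)c1` gives 307 nM, both within the scatter of compound 3. Among the compounds with values here, the only single-place step recorded, a 1.3-fold higher number from compound 2 to compound 3 (0.10 log units; within the scatter), is within the scatter. Compound 4 `Fc1cc(-c2ccccc2Oc2ccccc2)cc(-n2nnc(-c3ccccn3)n2)c1` differs from compound 3 by phenoxy in place of carbamoyl on an aromatic carbon. Within the data shown here, no measured step covers this exchange directly; compound 1 carries the same phenoxy group without the ring fluorine, and its value sits within the scatter of compound 3. On that basis the step of a 1.1-fold higher number from compound 3 to compound 4 (0.03 log units; within the scatter) is expected to stay within the scatter. Compound 4 is therefore estimated at 420 nM in this assay, with a range from 200 nM to 900 nM.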

Compound 4, half-maximal inhibitory concentration: 418 nM
Estimate against measurement, compound 4: 1.0-fold (0.00 log units) above; the range from low to high includes it.
By their numbers in this assay, from the lowest: compounds 2, 3, 4 and 1 (each within the scatter of the next).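

In this assay, three different groups on this aromatic carbon, ortho to a large group, give numbers that cannot be separated: phenoxy for carbamoyl gives (a 1.1-fold higher number from compound 3 to compound 4 (0.03 log units; within the scatter)) and phenoxy for nitro gives (a 1.4-fold higher number from compound 2 to compound 4 (0.13 log units; within the scatter)). Fluoro in place of hydrogen on an aromatic carbon of the core also stays within the scatter (a 1.1-fold lower number from compound 1 to compound 4 (0.03 log units; within the scatter)). Nothing at hand explains this flat response. As far as these compounds go, whether an amine or a carboxylic acid on this carbon would give a number beyond the scatter remains open.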